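Piperidin-1-yl Gives Way to 1H-1,2,4-Triazol-1-yl

The source may report more compounds than this note shows. Statements on the series, on what has been measured and on what is new or still open speak of the compounds shown alone.

Compound 1 `CCC(C)(C)Cc1c[nH]c(CCc2ccc(-c3csnn3)cc2)n1` gives 109 nM in a functional assay on HEK293 cells for agonist activity at Bombesin receptor subtype-3 (Mus musculus), read by luminescence and calcium flux, with a stated time of 10 min; a lower number here means that less compound is needed, a higher number that more compound is needed for the effect.
Compound 2 `CCC(C)(C)Cc1c[nH]c(CCc2ccc(N3CCCCC3)cc2)n1` gives 133 nM in this assay.
Compound 3 `O=C(O)c1cc(F)c(F)cc1-c1ccc(CCc2nc(CC3CCCCC3)c[nH]2)cc1` gives 96 nM in this assay.

Among these three, the number for compound 2 is nominally the largest, but the step of a 1.2-fold higher number from compound 1 to compound 2 (0.09 log units; within the scatter) lies within the scatter, and the gap between compound 2 and compound 3 is also within the scatter, so the three compounds cannot be told apart on these numbers.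

Compound 4 `CCC(C)(C)Cc1c[nH]c(CCc2ccc(-n3cncn3)cc2)n1` differs from compound 2 in one place: 1H-1,2,4-triazol-1-yl in place of piperidin-1-yl on an aromatic carbon. Within the data shown here, the only measured step that bears on this is the one from compound 1 to compound 2, where a five-membered aromatic ring with hetero atoms gave way to piperidin-1-yl, and that step stayed within the scatter. The present change returns a five-membered aromatic ring with three hetero atoms to the same place, so the step of a 1.2-fold lower number from compound 2 to compound 4 (0.08 log units; within the scatter) is expected to stay within the scatter too. Compound 4 is therefore estimated at 110 nM, with a range from 45 nM to 270 nM.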

Compound 4, half-maximal effective concentration: 121 nM
Compound 4: middle estimate off by 1.1-fold (0.04 log units), on the low side; the measured number falls inside the stated range.
By their numbers in this assay, from the lowest: compounds 3, 1, 4 and 2 (each within the scatter of the next).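

At the place para to a large group, the step of a 1.1-fold lower number from compound 2 to compound 4 (0.04 log units; within the scatter) in this assay shows that a five-membered aromatic ring with 3 hetero atoms and a six-membered non-aromatic ring with 1 hetero atom cannot be told apart, although they differ in ring type and in hydrogen-bond acceptor count. The step of a 1.1-fold higher number from compound 1 to compound 4 (0.05 log units; within the scatter) adds that 1H-1,2,4-triazol-1-yl and 1,2,3-thiadiazol-4-yl also cannot be told apart, so all three groups at this place, on the same core, give numbers within the scatter of one another. No measurement shown here accounts for this result.

As far as these compounds go, it remains open whether a much smaller group at this place, such as a primary amine or a nitrile, would also stay within the scatter. Compound 3 differs from these compounds in more than one place, so it does not settle that question.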